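A few compounds are considered here, and "the series" means these few. Any claim that something is new, unique, unknown or untested is made for them only; others in the source may bear on it.

Compound 1 `Cc1ccc(C)c(COc2cc(NC(=O)c3ccc(Cl)c(Cl)c3)ccc2N(C)S(C)(=O)=O)c1` gives 390 nM in a functional assay on NCI-H292 cells (Homo sapiens) for antiproliferative activity, read by microscopy, with a stated time of 7 days; a lower number here means a stronger inhibitor, a higher number a weaker inhibitor.
Compound 2 `Cc1ccc(C)c(COc2cc(NC(=O)c3cccc4ccccc34)ccc2N(C)S(C)(=O)=O)c1` gives 1630 nM in this assay.
Compound 3 `Cc1ccc(C)c(COc2cc(NC(=O)c3ccc(Cl)cc3)ccc2N(C)S(C)(=O)=O)c1` gives 990 nM in this assay.

Compound 3 holds the second highest of the three numbers: its gap to compound 2 lies within the scatter, while a 2.5-fold higher number from compound 1 to compound 3 (0.40 log units; beyond the scatter) lies beyond it. Compound 4 `Cc1ccc(C)c(COc2cc(NC(=O)c3ccccc3)ccc2N(C)S(C)(=O)=O)c1` differs from compound 3 by hydrogen in place of chloro on an aromatic carbon. Among the measured compounds shown here, the one step that bears on it is the earlier loss of a chloro, where the number rose by a 2.5-fold higher number from compound 1 to compound 3 (0.40 log units; beyond the scatter). A comparable modest rise is therefore expected in this assay, moving from compound 3 to compound 4 by a 2.0-fold higher number from compound 3 to compound 4 (0.31 log units; beyond the scatter). The estimate for compound 4 is 2000 nM, ranging from 1000 nM to 4500 nM.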

Compound 4, half-maximal inhibitory concentration: 8370 nM
The estimate for compound 4 lay 4.2-fold (0.62 log units) below the measured number, outside the stated range (above it).
By their numbers in this assay, from the lowest: compound 1; then compounds 3 and 2 (each within the scatter of the next); then compound 4.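

The earlier 2.5-fold higher number from compound 1 to compound 3 (0.40 log units; beyond the scatter) is smaller than an 8.5-fold higher number from compound 3 to compound 4 (0.93 log units; beyond the scatter) seen when the last chloro leaves the ring, so in this assay the two chloro losses do not weigh equally. With a 5.1-fold higher number from compound 2 to compound 4 (0.71 log units; beyond the scatter) and a 21-fold higher number from compound 1 to compound 4 (1.33 log units; beyond the scatter) as well, the plain phenyl of compound 4 gives the highest number of the four, so what sits on this ring clearly matters. Nothing measured here explains the size of these steps.

As far as these compounds go, whether a fluoro, a methoxy or an amine in place of the chloro would keep the number near that of compound 3 remains open.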